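The source may hold more compounds than are shown below. What is called first, only, known or untested is meant among the compounds shown, and "the series" means these compounds.

Measured in a toxicity assay on HUVEC cells (Homo sapiens) for cytotoxicity, read by MTT assay, with a stated time of 96 h; a higher number here means a weaker inhibitor, a lower number a stronger inhibitor:
Compound 1 `O=C1NC(=O)/C(=C\c2ccc(OCC(=O)N3N=C(c4ccccc4)CC3c3ccccc3Cl)cc2)S1`: 2000 nM
Compound 2 `O=C1NC(=O)/C(=C\c2ccc(OCC(=O)N3N=C(c4ccc(F)cc4)CC3c3ccccc3)cc2)S1`: > 10000 nM

Compound 2 stands at > 10000 nM, which is a limit of this assay and not a number. For the measured compounds named here, its true position is therefore unknown, and the limit of > 10000 nM in this assay, at which 1 of the 2 values shown sits, is the only information on that point. Going by the values given here, compound 1, at 2000 nM, gives the only numerical reading in this assay.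

Compound 3 `O=C1NC(=O)/C(=C\c2ccc(OCC(=O)N3N=C(c4ccc(F)cc4)CC3c3ccco3)cc2)S1` keeps the rest of compound 2 and carries furan-2-yl in place of phenyl on a saturated ring carbon. Among the compounds with values here, no step between measured compounds gauges this change, so no step beyond the scatter is expected. The expected step is an at least 1.2-fold lower number from compound 2 to compound 3 (0.09 log units; that floor lies within the scatter). For compound 3 the estimated value in this assay is 8000 nM, with an expected range from 2500 nM to 25000 nM.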

Compound 3, half-maximal inhibitory concentration: 700 nM
Beside the measured number, compound 3's estimate is 11-fold (1.06 log units) above it; the measured number lies below the stated range.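

For the compounds shown here, until compound 3, no pair of measured compounds gauged any change at this position. In this assay, furan-2-yl in place of phenyl on the saturated ring carbon gives an at least 14-fold lower number from compound 2 to compound 3 (1.15 log units; beyond the scatter), so with the 4-fluorophenyl group kept, the number read here does respond to the group at this carbon. Compound 2 stands at a limit and not at a number, so this step is a floor and its true size remains unknown: the limit of > 10000 nM in this assay, at which 1 of the 3 values shown sits.

The compounds shown leave open whether the lower number goes with the ring oxygen or with the five-membered ring as such, which thiophen-2-yl or furan-3-yl at this carbon would help to separate. They also leave open whether the step persists when a group such as pyridin-2-yl or cyclopentyl sits at this carbon, or when the 4-fluorophenyl group is replaced.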